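Taking One Methoxy from Compound 2

This account rests on a few compounds, and the source may have more. Where it says the series, first, only, none or still open, it means among the compounds named here.

Going by the values given here, in a functional assay on A549 cells (Homo sapiens) for cytotoxicity, read by MTT assay, with a stated time of 48 h (a higher number here means a weaker inhibitor, a lower number a stronger inhibitor), compound 1 `C=CCn1c(-c2cc(OC)c(OC)cc2COCOC)cc2ccccc2c1=O` gives 88100 nM, while compound 2 `C=CCn1c(-c2cc(OC)c(OC)cc2C=C)cc2ccccc2c1=O` gives 43200 nM, the lower of the two numbers so far. Compound 3 `C=CCn1c(-c2ccc(OC)cc2C=C)cc2ccccc2c1=O` departs from compound 2 at a single place: hydrogen in place of methoxy on an aromatic carbon. It carries hydrogen in place of methoxy on an aromatic carbon, ortho to a methoxy group and para to a vinyl group.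

Among the compounds with values here, no measured step removes or replaces a methoxy group, so the data give no direct reading of this change. Within the data shown here, the only measured step, a 2.0-fold lower number from compound 1 to compound 2 (0.31 log units; beyond the scatter), involves vinyl in place of (methoxymethoxy)methyl on an aromatic carbon. It is modest and beyond the scatter, but it is a different change and can serve only as a rough guide to size. A step of about that size at most is therefore expected in this assay, with no direction favoured and quite possibly nothing beyond the scatter. The expected change is a 1.1-fold lower number from compound 2 to compound 3 (0.03 log units; within the scatter). Compound 3 is estimated at 40000 nM, with an expected range from 18000 nM to 90000 nM.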

Compound 3, half-maximal inhibitory concentration: 17200 nM
Compound 3: the middle estimate sits 2.3-fold (0.37 log units) above what was measured; measured number outside the range, below it.
By their numbers in this assay, from the lowest: compound 3; then compound 2; then compound 1.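

In this assay, the methoxy group that is para to a vinyl group and ortho to a second methoxy group can be replaced by hydrogen without any loss, and the number in fact falls, with a 2.5-fold lower number from compound 2 to compound 3 (0.40 log units; beyond the scatter). Going by these compounds alone, this is the first reading at this position, and it gives what the earlier compounds could not: a direction for this change, which here favours the compound with hydrogen and shows that this methoxy group is not required for the activity seen in this pair. No measurement in hand explains why the number falls, so the step stands as an observation only.

The compounds shown leave open whether the gain comes simply from the absence of a group at this position, or whether a fluorine atom, a hydroxyl group or an ethoxy group there would give a similar number. They also leave open whether the remaining methoxy group can be replaced by hydrogen in the same way, and whether this step would hold with (methoxymethoxy)methyl in place of the vinyl group.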